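The source may report more compounds than this note shows. Statements on the series, on what has been measured and on what is new or still open speak of the compounds shown alone.

Measured compounds:
- Compound 1, `O=C(CSc1nc2ccc(NC(=O)CCl)cc2s1)NCc1ccccc1`: 4200 nM in a functional assay on MCF7 cells (Homo sapiens) for cytotoxicity, read by MTT assay, with a stated time of 48 h; a higher number here means a weaker inhibitor, a lower number a stronger inhibitor
- Compound 2, `O=C(CSc1nc2ccc(NC(=O)c3ccc([N+](=O)[O-])cc3)cc2s1)NCc1ccccc1`: > 100000 nM, which is a limit of the assay and not a measured number

Compound 2 stands at the limit of > 100000 nM in this assay, at which 1 of the 2 values shown sits, so all that is known of it in this assay is that it is weaker than the assay can resolve; no number has been obtained for it. The next compound, compound 3, `COc1ccccc1C(=O)Nc1ccc2nc(SCC(=O)NCc3ccccc3)sc2c1`, differs from compound 2 in one place: 2-methoxyphenyl in place of 4-nitrophenyl on a carbonyl carbon. Among the measured compounds shown here, only one measured step exists, an at least 23-fold higher number from compound 1 to compound 2 (1.37 log units; beyond the scatter), and it runs from a chloromethyl amide to an aryl amide, not from one aryl amide to another. It therefore bears on compound 3 only indirectly, by showing that placing an aryl group on that carbonyl carbon gave a compound at the assay limit. Compound 3 also carries an aryl group there, so no step beyond the scatter is expected from compound 2, and the result may well be another limit. The step of a number no higher from compound 2 to compound 3 (the limit leaves the size open) is the expected outcome for compound 3. The estimate for compound 3 is 100000 nM, with a range from 20000 nM to 400000 nM.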

Compound 3, half-maximal inhibitory concentration: 17200 nM
Compound 3: middle estimate off by 5.8-fold (0.76 log units), on the high side; measured number below the stated range.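

In this assay, swapping 4-nitrophenyl for 2-methoxyphenyl on this carbonyl carbon gives an at least 5.8-fold lower number from compound 2 to compound 3 (0.76 log units; beyond the scatter) and so shows that an aryl amide here need not sit beyond the reach of the assay: which aryl group is attached makes a difference. On these data alone, the full size of that step stays open, because compound 2 is held by a limit of the assay and not by a measured number: the limit of > 100000 nM in this assay, at which 1 of the 3 values shown sits. Placing 2-methoxyphenyl where compound 1 has chloromethyl gives a 4.1-fold higher number from compound 1 to compound 3 (0.61 log units; beyond the scatter) and leaves compound 1 the strongest of the three.

Compound 2 and compound 3 differ both in the group on the ring and in where it sits, as the names 4-nitrophenyl and 2-methoxyphenyl show, so the compounds shown cannot separate these two changes, and 4-methoxyphenyl or 2-nitrophenyl would be needed to do so. Also open, as far as these compounds go, is how a plain phenyl, a 4-aminophenyl or a longer chain such as 3-chloropropyl would fare on the same carbonyl carbon.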